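Aryl amines on the shared core: outlook for compound 4

A few compounds are considered here, and "the series" means these few. Any claim that something is new, unique, unknown or untested is made for them only; others in the source may bear on it.

In a functional assay on HGC-27 cells (Homo sapiens) for cytotoxicity, read by MTT assay, with a stated time of 72 h (on this read-out higher numbers stand for weaker inhibition and lower numbers for stronger inhibition), compound 3 `COc1ccccc1Nc1nc(SCc2ccc(C(F)(F)F)cc2)nc2ccccc12` gives only a limit, > 50000 nM. Compound 1 `CCCCCCNc1nc(SCc2ccc(C(F)(F)F)cc2)nc2ccccc12` gives 23900 nM in this assay. Compound 2 `FC(F)(F)c1ccc(CSc2nc(Nc3ccccc3Cl)c3ccccc3n2)cc1` likewise sits at a limit, > 50000 nM. The steps of an at least 2.0-fold higher number from compound 1 to compound 3 (0.32 log units; beyond the scatter) and an at least 2.0-fold higher number from compound 1 to compound 2 (0.32 log units; beyond the scatter) both run toward weaker inhibition, while a step that the two limits leave unreadable from compound 2 to compound 3, since the limit of > 50000 nM in this assay, at which 2 of the 3 values shown sit, hides the true sizes. Compound 4 `FC(F)(F)c1ccc(CSc2nc(Nc3cccc(Br)c3)c3ccccc3n2)cc1` differs from compound 3 by 3-bromophenyl in place of 2-methoxyphenyl on a nitrogen on an aromatic ring. Given an at least 2.0-fold higher number from compound 1 to compound 2 (0.32 log units; beyond the scatter) and an at least 2.0-fold higher number from compound 1 to compound 3 (0.32 log units; beyond the scatter), a third aryl group at the same nitrogen is expected to leave compound 4 near the limit of this assay, at an estimated 50000 nM with a range of 18000 nM to 150000 nM. The expected step is therefore a number no higher from compound 3 to compound 4 (the limit leaves the size open), with a real chance that only a limit is reported.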

Compound 4, half-maximal inhibitory concentration: 18300 nM
For compound 4 the middle estimate is 2.7-fold (0.44 log units) above the measured one, within the range that was stated.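

In this assay, an aryl group on this nitrogen does not by itself carry the loss: 3-bromophenyl in place of 2-methoxyphenyl gives an at least 2.7-fold lower number from compound 3 to compound 4 (0.43 log units; beyond the scatter), and in place of 2-chlorophenyl it gives an at least 2.7-fold lower number from compound 2 to compound 4 (0.43 log units; beyond the scatter). Set against hexyl, it gives a 1.3-fold lower number from compound 1 to compound 4 (0.12 log units; within the scatter), so these two groups cannot be told apart here.

On these data alone, the step from compound 2 to compound 3 cannot be read, and the true sizes of the steps from those two to compound 4 stay open: the limit of > 50000 nM in this assay, at which 2 of the 4 values shown sit. Also open is whether bromine or its place on the ring matters, and how an unsubstituted phenyl amine or a benzyl amine would read.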